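From 2-fluorophenyl to 4-chlorophenyl on a shared core

This account rests on a few compounds, and the source may have more. Where it says the series, first, only, none or still open, it means among the compounds named here.

In a functional assay on WM 266-4 cells (Homo sapiens) for antiproliferative activity, read by MTT assay, with a stated time of 24 h (on this read-out lower numbers stand for stronger inhibition of growth and higher numbers for weaker inhibition of growth), compound 1 `c1ccc(N2N=C(c3ccc4c(c3)OCCO4)CC2c2ccco2)cc1` gives > 100000 nM, which is a limit of the assay and not a number. Of the two true numbers, compound 3 `Fc1ccccc1C1CC(c2ccc3c(c2)OCCO3)=NN1c1ccccc1` has the higher, 9120 nM, while compound 2 `Ic1ccc(C2CC(c3ccc4c(c3)OCCO4)=NN2c2ccccc2)cc1` gives 3470 nM. Compound 4 `Clc1ccc(C2CC(c3ccc4c(c3)OCCO4)=NN2c2ccccc2)cc1` carries 4-chlorophenyl in place of 2-fluorophenyl on a saturated ring carbon. The large steps of an at least 28-fold lower number from compound 1 to compound 2 (1.45 log units; beyond the scatter) and an at least 10-fold lower number from compound 1 to compound 3 (1.04 log units; beyond the scatter) start from furan-2-yl, so they bear on this change only loosely. The closer guide is a 2.6-fold higher number from compound 2 to compound 3 (0.42 log units; beyond the scatter), since 4-iodophenyl in compound 2 most resembles 4-chlorophenyl. A modest fall is therefore expected in this assay, an estimated 2.2-fold lower number from compound 3 to compound 4 (0.34 log units; beyond the scatter). For compound 4 the expected value is 4200 nM, within an estimated range of 1500 nM to 12000 nM.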

Compound 4, concentration for 50% growth inhibition: 38600 nM
Compound 4: the middle estimate sits 9.2-fold (0.96 log units) below what was measured, outside the stated range (above it).
By their numbers in this assay, from the lowest: compound 2; then compound 3; then compound 4. At a limit, above all of these: compound 1.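

For the compounds shown here, exchanging iodo for chloro on an aromatic carbon, the only change, gives an 11-fold higher number from compound 2 to compound 4 (1.05 log units; beyond the scatter), so the halogen matters far more here than compound 2 suggested. The 4-chlorophenyl group also compares poorly with 2-fluorophenyl, with a 4.2-fold higher number from compound 3 to compound 4 (0.63 log units; beyond the scatter), so a halogen on the phenyl group does not by itself secure a low number. Compound 1 stands at a limit, so an at least 2.5-fold lower number from compound 1 to compound 4 (0.41 log units; beyond the scatter) gives only a bound on the gain over furan-2-yl: the limit of > 100000 nM in this assay, at which 1 of the 4 values shown sits.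

From the compounds shown here alone, whether 4-bromophenyl would land nearer compound 2 or compound 4 remains open. So does the effect of a phenyl group carrying methoxy or an amine at this position.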